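Swapping the amide's aryl ring in a flavonol series

The source may hold more compounds than are shown below. What is called first, only, known or untested is meant among the compounds shown, and "the series" means these compounds.

Three compounds share a core and differ only in the ring attached to the amide carbonyl. Compound 1 `COc1ccccc1C(=O)Nc1cccc(-c2oc3cc(-c4ccc(F)cc4)ccc3c(=O)c2O)c1` gives in a functional assay on HepG2 cells (Homo sapiens) for antiproliferative activity, read by CCK-8 assay, with a stated time of 72 h (a higher number here means a weaker inhibitor, a lower number a stronger inhibitor), a value of 14500 nM. Compound 2 `O=C(Nc1cccc(-c2oc3cc(-c4ccc(F)cc4)ccc3c(=O)c2O)c1)c1ccc(C(F)(F)F)cc1` gives in this assay 42700 nM. Compound 3 `Cc1cccc(C(=O)Nc2cccc(-c3oc4cc(-c5ccc(F)cc5)ccc4c(=O)c3O)c2)c1` gives in this assay 13500 nM, the lowest number of the three, though its gap to compound 1 is within the scatter a 1.1-fold lower number from compound 1 to compound 3 (0.03 log units; within the scatter), so the two cannot be ranked; only the gap to compound 2 is beyond it a 3.2-fold lower number from compound 2 to compound 3 (0.50 log units; beyond the scatter).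

Compound 4 `O=C(Nc1cccc(-c2oc3cc(-c4ccc(F)cc4)ccc3c(=O)c2O)c1)c1ccc(Cl)nc1` differs from compound 3 in this change: 6-chloropyridin-3-yl in place of 3-methylphenyl on a carbonyl carbon. Among the measured compounds shown here, the steps that bear on it are the ring swaps already seen, a 2.9-fold higher number from compound 1 to compound 2 (0.47 log units; beyond the scatter) and a 3.2-fold lower number from compound 2 to compound 3 (0.50 log units; beyond the scatter), both modest, and a 1.1-fold lower number from compound 1 to compound 3 (0.03 log units; within the scatter), within the scatter. A ring swap at this carbonyl has so far moved the number only modestly, so for compound 4 a modest step is expected, most likely toward a higher number, a 1.6-fold higher number from compound 3 to compound 4 (0.21 log units; within the scatter). The expected value for compound 4 is 22000 nM, with a range from 8000 nM to 60000 nM.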

Compound 4, half-maximal inhibitory concentration: 4610 nM
Estimate against measurement, compound 4: 4.8-fold (0.68 log units) above, and the stated range ends above it.
By their numbers in this assay, from the lowest: compound 4; then compounds 3 and 1 (each within the scatter of the next); then compound 2.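

Among the compounds shown here, the 6-chloropyridin-3-yl ring of compound 4 is the first ring in this set to carry a ring nitrogen and a chlorine, and it gives the strongest result so far in this assay, with a 2.9-fold lower number from compound 3 to compound 4 (0.47 log units; beyond the scatter) and a 3.1-fold lower number from compound 1 to compound 4 (0.50 log units; beyond the scatter). The widest gap, a 9.3-fold lower number from compound 2 to compound 4 (0.97 log units; beyond the scatter), shows that the ring on this carbonyl can move the number further than compounds 1, 2 and 3 alone suggested. Nothing measured here accounts for the gain.

The compounds shown do not separate the ring nitrogen from the chlorine, since a pyridin-3-yl ring without chlorine or a chlorophenyl ring would each carry only one of the two. Also open, on these data alone, is whether the gain would hold with an amine or a nitrile in place of the chlorine.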